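Swapping chloro and fluoro positions on the biaryl ring

The compounds below may be only part of what the source reports. "The series", "measured", "known", "first", "only" and "open" are said of these compounds alone.

Measured so far:
Compound 1 `Fc1ccc(-c2ccc(Cn3nnc4ccccc43)cc2)c(F)c1`: 6.4 mL/min/g
Compound 2 `Fc1cc(Cl)ccc1-c1ccc(Cn2nnc3ccccc32)cc1`: 1.3 mL/min/g

In an ADME assay on microsomes from liver (Rattus norvegicus, strain Wistar) for metabolic stability, tested at 2.5 uM (a higher number here means faster removal of the compound, a lower number slower removal), compound 2 gives the lowest of the two numbers, with compound 1 the nearest at 6.4 mL/min/g. Compound 3 `Fc1ccc(-c2ccc(Cn3nnc4ccccc43)cc2)c(Cl)c1` differs from compound 2 by 2-chloro-4-fluorophenyl in place of 4-chloro-2-fluorophenyl on an aromatic carbon. Among the compounds with values here, the only step that bears on this is a 4.9-fold lower number from compound 1 to compound 2 (0.69 log units; beyond the scatter), which placed chloro on the ring; compound 3 keeps that chloro, but in the other position, so the size of that effect is not secured. Compound 3 is therefore expected to land between its two neighbours, a moderate rise of a 2.3-fold higher number from compound 2 to compound 3 (0.36 log units; beyond the scatter), giving an estimated 3 mL/min/g with a range from 1.2 mL/min/g to 8 mL/min/g.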

Compound 3, intrinsic clearance in a liver preparation (reported as CLH), per the amount of preparation that the assay uses: 2.6 mL/min/g
Compound 3: the middle estimate sits 1.2-fold (0.06 log units) above what was measured, and the stated range covers the measured number.
By their numbers in this assay, from the lowest: compounds 2 and 3 (each within the scatter of the next); then compound 1.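

In this assay, 2-chloro-4-fluorophenyl in place of 4-chloro-2-fluorophenyl gives a 2.0-fold higher number from compound 2 to compound 3 (0.30 log units; within the scatter) and so, at this place, the two arrangements of the same atoms are not told apart. Chloro in place of fluoro gives a 2.5-fold lower number from compound 1 to compound 3 (0.39 log units; beyond the scatter) in this second arrangement, in the same direction as a 4.9-fold lower number from compound 1 to compound 2 (0.69 log units; beyond the scatter) in the first. Nothing available explains these numbers.

Going by these compounds, how a methoxy group or an amine in place of the chloro would read in this assay remains open. So does the reading of a phenyl ring carrying no halogen.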